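This account rests on a few compounds, and the source may have more. Where it says the series, first, only, none or still open, it means among the compounds named here.

In a functional assay on SW-620 cells (Homo sapiens) for inhibition, read by sulforhodamine B assay, with a stated time of 48 h, tested at 10 uM (on this read-out higher numbers stand for more inhibition at the one concentration tested (going by the name of the read-out) and lower numbers for less inhibition), three compounds have been measured so far:

Compound 1 `O=Cc1ccc(-c2cn3ccnc3c(-c3ccc4ncn(C5CCCCC5)c4c3)n2)cc1`: 4.21%
Compound 2 `c1ccc2c(-c3cn4ccnc4c(-c4ccc5ncn(C6CCCCC6)c5c4)n3)cccc2c1`: 5.34%
Compound 3 `Fc1ccc(-c2cn3ccnc3c(-c3ccc4ncn(C5CCCCC5)c4c3)n2)cc1`: 8.38%

Compound 1 has the lowest of the three numbers, but its neighbours sit close by: compound 2 is a number 1.1 percentage points higher from compound 1 to compound 2 (within the scatter) and compound 3 is a number 4.2 percentage points higher from compound 1 to compound 3 (within the scatter). Both steps lie within the usual scatter of repeated measurements, so none of the three can be said to inhibit the cells more or less than another; all of them show little inhibition at the concentration tested. The three share one core and differ only in the aryl group attached to it.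

Compound 4 `Fc1ccccc1-c1cn2ccnc2c(-c2ccc3ncn(C4CCCCC4)c3c2)n1` is the next member of this set. Against compound 1 the change is 2-fluorophenyl in place of 4-formylphenyl on an aromatic carbon. For the measured compounds named here, two measured steps bear on this. The nearest is the one that also puts a fluorine in place of the formyl group, though as 4-fluorophenyl rather than 2-fluorophenyl, a number 4.2 percentage points higher from compound 1 to compound 3 (within the scatter). The other replaces the same 4-formylphenyl with a quite different aryl group, a number 1.1 percentage points higher from compound 1 to compound 2 (within the scatter). Neither moved the read-out beyond the scatter, and nothing among these compounds suggests that the new group would behave differently. The step from compound 1 to compound 4 is therefore expected to be a number 2.8 percentage points higher from compound 1 to compound 4 (within the scatter), within the scatter. Compound 4 is estimated at 7%, with a range from 0% to 16%.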

Compound 4, a percentage reported as inhibition, at one concentration (the size of the read-out at that concentration, not a potency): 9.53%
Compound 4: the middle estimate sits 2.5 percentage points below what was measured, within the range that was stated.
By their numbers in this assay, from the lowest: compounds 1, 2, 3 and 4 (each within the scatter of the next).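

In this assay, the new compound tests where the fluorine sits on the phenyl ring attached to this aromatic carbon, next to the ring nitrogen: 2-fluorophenyl in place of 4-fluorophenyl gives a small step (a number 1.2 percentage points higher from compound 3 to compound 4 (within the scatter)), so the two placements of fluorine cannot be told apart here. The other two comparisons agree, with 2-fluorophenyl in place of 4-formylphenyl (a number 5.3 percentage points higher from compound 1 to compound 4 (within the scatter)) and in place of naphthalen-1-yl (a number 4.2 percentage points higher from compound 2 to compound 4 (within the scatter)), which means that all four aryl groups seen so far at this position give numbers within the scatter of one another. No measurement shown here offers an explanation for this flat result.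

For the compounds shown here, every group at this position so far is built on an aromatic ring of carbon only, so it remains open whether a phenyl ring carrying an amine or a carboxylic acid, or a ring containing nitrogen such as pyridine, would move the read-out beyond the scatter. Going by these compounds, the cyclohexyl group is also the same in all four compounds, so what would follow from exchanging it for a shorter chain such as ethyl remains unknown.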